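The compounds below may be only part of what the source reports. "The series", "measured", "known", "first", "only" and "open" are said of these compounds alone.

Measured compounds:
compound 1 `CS/C(=N\C(=O)c1cc2ccccc2s1)NC(=O)c1cc2ccccc2s1`, 78500 nM
compound 2 `O=C(/N=C(/NC(=O)c1cccs1)[Se]Cc1ccccc1)c1cccs1`, > 100000 nM
compound 3 `CS/C(=N\C(=O)c1cccs1)NC(=O)c1cccs1`, > 100000 nM

Among the measured compounds shown here, in a functional assay on MCF7 cells (Homo sapiens) for cytotoxicity, read by MTT assay, with a stated time of 72 h (on this read-out lower numbers stand for higher toxicity in this test and higher numbers for lower toxicity in this test), compound 1 gives 78500 nM, the only number among the three. Compound 2 gives only a limit, > 100000 nM. Compound 3 likewise gives only a limit, > 100000 nM. Compound 2 differs from compound 3 by a group of 8 heavy atoms (7 carbon, 1 selenium; one six-membered aromatic ring of carbon only) in place of a group of 2 heavy atoms (1 carbon, 1 sulfur; no ring), on a carbon with a double bond to nitrogen, yet the two limits leave this step unreadable: a step that the two limits leave unreadable from compound 3 to compound 2. The difference between the core of compound 1 and the core of compound 3 is not broken down here.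

Compound 4 `O=C(/N=C(/NC(=O)c1cc2ccccc2s1)[Se]Cc1ccccc1)c1cc2ccccc2s1` has not yet been measured in this assay. It differs from compound 1 by a group of 8 heavy atoms (7 carbon, 1 selenium; one six-membered aromatic ring of carbon only) in place of a group of 2 heavy atoms (1 carbon, 1 sulfur; no ring), on a carbon with a double bond to nitrogen, the same change already seen from compound 3 to compound 2. Since that step is unreadable and two of the three values sit at the limit of > 100000 nM in this assay, at which 2 of the 3 values shown sit, there is little to set the size of the coming step. Compound 4 is expected to give 110000 nM, between 40000 nM and 300000 nM. The expected size of the step is a 1.4-fold higher number from compound 1 to compound 4 (0.15 log units; within the scatter), resting on the unreadable step that the two limits leave unreadable from compound 3 to compound 2 and on the limit of > 100000 nM in this assay, at which 2 of the 3 values shown sit, at which compounds 2 and 3 sit.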

Compound 4, concentration lethal to 50% of the cells: 87900 nM
Beside the measured number, compound 4's estimate is 1.3-fold (0.10 log units) above it, and the stated range covers the measured number.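

On the core of compound 1, putting the selenium-bearing group with its six-membered aromatic ring in place of methylsulfanyl, on a carbon with a double bond to nitrogen, gives a 1.1-fold higher number from compound 1 to compound 4 (0.05 log units; within the scatter) in this assay, so this swap leaves no readable difference on this core. The same swap on the core of compound 3 cannot be read, so this single step has no readable counterpart, and nothing shows whether the change carries over from one core to the other. Compound 2 and compound 3 each give only a limit of the assay and not a number, and this confines the readable comparison to one core: the limit of > 100000 nM in this assay, at which 2 of the 4 values shown sit.

The compounds shown leave open whether an amine, a carboxylic acid or a longer chain on that same carbon would give a step beyond the scatter. They also leave open how the two groups seen here would compare on a further core whose values all fall within the readable range.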